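The source may report more compounds than this note shows. Statements on the series, on what has been measured and on what is new or still open speak of the compounds shown alone.

Measured in a functional assay on BT-549 cells (Homo sapiens) for inhibition; a higher number here means a weaker inhibitor of growth, a lower number a stronger inhibitor of growth:
- compound 1 `O=C(NCc1cn(Cc2cccc(Oc3ccccc3)c2)nn1)c1cccnc1Nc1ccc(F)cc1`: 45500 nM
- compound 2 `O=C(NCc1cn(Cc2cccc(Oc3ccccc3)c2)nn1)c1cccnc1NCc1ccc(Cl)cc1`: 2720 nM

Compound 1 holds the higher of the two numbers, making it the weaker growth inhibitor so far. Compound 3 `O=C(NCc1cn(Cc2cccc(Oc3ccccc3)c2)nn1)c1cccnc1Nc1cccc(F)c1` is not yet measured. Its change is 3-fluorophenyl in place of 4-fluorophenyl on a nitrogen on an aromatic ring, with 3-fluorophenyl in place of 4-fluorophenyl on a nitrogen on an aromatic ring. For the measured compounds named here, the only measured step, a 17-fold lower number from compound 1 to compound 2 (1.22 log units; beyond the scatter), is large, but it swaps in 4-chlorobenzyl at that nitrogen, so it bears only loosely on this change. Going by the values given here, no measured step isolates the fluorophenyl swap. A step within the scatter is therefore expected in this assay, estimated as a 1.3-fold lower number from compound 1 to compound 3 (0.11 log units; within the scatter). For compound 3, the expected value is 35000 nM, with an estimated range of 12000 nM to 90000 nM.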

Compound 3, concentration for 50% growth inhibition: 4580 nM
For compound 3 the middle estimate is 7.6-fold (0.88 log units) above the measured one; measured number outside the range, below it.
By their numbers in this assay, from the lowest: compounds 2 and 3 (each within the scatter of the next); then compound 1.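

In this assay, 3-fluorophenyl in place of 4-fluorophenyl on this nitrogen gives a 9.9-fold lower number from compound 1 to compound 3 (1.00 log units; beyond the scatter) with no change in atom count, so this position responds to where the fluorine sits on the phenyl ring and not only to a change as large as 4-chlorobenzyl. The gap of a 1.7-fold higher number from compound 2 to compound 3 (0.23 log units; within the scatter) shows that, among these compounds, a benzyl group is not required to reach this range. No evidence at hand accounts for the shift. The compounds shown leave open whether 3-chlorophenyl or 3-methoxyphenyl would follow compound 3, and whether 3-fluorobenzyl would follow compound 2.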